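This account rests on a few compounds, and the source may have more. Where it says the series, first, only, none or still open, it means among the compounds named here.

Three compounds share one core and differ only at the aryl group on the ring-bound nitrogen and at the basic amine on the ether chain. Compound 1 `COc1cc2c(Oc3ccc(NC(=O)c4nn(-c5ccc(Br)cc5)c(=O)c5ccccc45)cc3F)ccnc2cc1OCCCN1CCCC1` gives 1160 nM in a functional assay on MDA-MB-231 cells (Homo sapiens) for cytotoxicity, read by MTT assay, with a stated time of 72 h; on this read-out higher numbers stand for weaker inhibition and lower numbers for stronger inhibition. Compound 2 `COc1cc2c(Oc3ccc(NC(=O)c4nn(-c5ccccc5)c(=O)c5ccccc45)cc3F)ccnc2cc1OCCCN1CCC(C)CC1` gives 1480 nM. Compound 3 `COc1cc2c(Oc3ccc(NC(=O)c4nn(-c5ccc(F)cc5)c(=O)c5ccccc45)cc3F)ccnc2cc1OCCCN1CCC(C)CC1` gives 660 nM, the lowest of the three numbers; compound 1 sits within the usual scatter of it, while compound 2 lies beyond it, the step of a 2.2-fold lower number from compound 2 to compound 3 (0.35 log units; beyond the scatter) coming from fluoro in place of hydrogen on an aromatic carbon.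

Compound 4 `COc1cc2c(Oc3ccc(NC(=O)c4nn(-c5ccc(Br)cc5)c(=O)c5ccccc45)cc3F)ccnc2cc1OCCCN1CCC(C)CC1` is not yet measured. Its difference from compound 3 is bromo in place of fluoro on an aromatic carbon. Going by the values given here, no single measured step swaps these two halogens alone; compound 1 carries bromo but also a different amine, and its value against compound 3 lies within the scatter. The expectation therefore is a step of a 1.3-fold higher number from compound 3 to compound 4 (0.11 log units; within the scatter), close to no change beyond the scatter. Compound 4 is estimated at 850 nM, within 400 nM to 1800 nM.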

Compound 4, half-maximal inhibitory concentration: 1160 nM
Estimate against measurement, compound 4: 1.4-fold (0.14 log units) below; the range from low to high includes it.
By their numbers in this assay, from the lowest: compounds 3, 1, 4 and 2 (each within the scatter of the next, the first and the last beyond it).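

With the 4-methylpiperidin-1-yl chain held fixed, swapping 4-fluorophenyl for 4-bromophenyl gives a 1.8-fold higher number from compound 3 to compound 4 (0.24 log units; within the scatter) and places the bromo compound within the scatter of the fluoro compound, while bromo in place of hydrogen gives a 1.3-fold lower number from compound 2 to compound 4 (0.11 log units; within the scatter) and places it within the scatter of the hydrogen compound as well. Only the fluoro and hydrogen compounds are separated at this position, so the halogens cannot be ranked against each other here. Going by these compounds alone, the first comparison of the two amines, with 4-bromophenyl held fixed, shows no change at the digits printed from compound 1 to compound 4 (within the scatter) and no measurement is available to explain any of these steps.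

The compounds shown leave open whether a chloro or methoxy group at this aromatic carbon would stand clearly apart from compound 2. They also leave open whether morpholine in place of these amines would shift the number beyond the scatter.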